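Trifluoromethoxy in place of methoxy on the shared core

This account rests on a few compounds, and the source may have more. Where it says the series, first, only, none or still open, it means among the compounds named here.

Measured so far:
- compound 1, `FC(F)(F)c1ccccc1-c1ccc2[nH]ncc2c1`: > 30000 nM
- compound 2, `COc1cc2[nH]ncc2cc1-c1ccccc1C(F)(F)F`: > 30000 nM

In an assay on CHO-K1 cells for antagonist activity at transient receptor potential cation channel subfamily V member 1 (Homo sapiens), read by FLIPR and calcium flux, with a stated time of 10 min (on this read-out lower numbers stand for stronger inhibition and higher numbers for weaker inhibition), compound 1 gives only a limit, > 30000 nM. In this assay compound 2 likewise gives only a limit, > 30000 nM. For the measured compounds named here, the one step between them, a step that the two limits leave unreadable from compound 1 to compound 2, cannot be read, since both ends sit at the limit of > 30000 nM in this assay, at which 2 of the 2 values shown sit. Compound 2 thus stands at the limit, with no number to place it against.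

Compound 3, `FC(F)(F)Oc1cc2[nH]ncc2cc1-c1ccccc1C(F)(F)F`, differs from compound 2 by trifluoromethyl in place of methyl on an oxygen on an aromatic ring. Going by the values given here, no measured step bears on this change; the only step available is unreadable, and nothing shows a readable value at all. The size of the step from compound 2 to compound 3 in this assay is therefore not predictable from the data, and the expected outcome for compound 3 is another limit, with the estimated step that the limit leaves unreadable from compound 2 to compound 3. Compound 3 is estimated at 40000 nM, within 5000 nM to 150000 nM.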

Compound 3, half-maximal inhibitory concentration: 11500 nM
Beside the measured number, compound 3's estimate is 3.5-fold (0.54 log units) above it; measured number inside the range.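

Compound 3 is the only compound shown with a number rather than a limit in this assay, so this place on the shared core can yield a readable value. Trifluoromethyl in place of methyl on an oxygen on an aromatic ring gives an at least 2.6-fold lower number from compound 2 to compound 3 (0.41 log units; beyond the scatter), and trifluoromethoxy in place of hydrogen on an aromatic carbon gives an at least 2.6-fold lower number from compound 1 to compound 3 (0.41 log units; beyond the scatter). Both steps are open-ended, and the step between the other two compounds cannot be read, as each of them stands at a limit: the limit of > 30000 nM in this assay, at which 2 of the 3 values shown sit.

From the compounds shown here alone, the true size of both steps remains open, as does whether a group such as an amine, a carboxylic acid or a longer alkoxy chain on the same aromatic carbon would also give a readable value. The compounds shown also leave open whether replacing the trifluoromethyl on the phenyl ring with a nitrile would keep the value of compound 3.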